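From 2-fluorophenyl to 4-chlorophenyl: what step to expect

A few compounds are considered here, and "the series" means these few. Any claim that something is new, unique, unknown or untested is made for them only; others in the source may bear on it.

- Compound 1 `C=CCOc1cc(OC)c(C(=O)/C=C/c2ccc(F)cc2)c(OCC=C)c1`: 13600 nM
- Compound 2 `C=CCOc1cc(OC)c(C(=O)/C=C/c2ccccn2)c(OCC=C)c1`: 2800 nM
- Compound 3 `C=CCOc1cc(OC)c(C(=O)/C=C/c2ccccc2F)c(OCC=C)c1`: 16300 nM

In an ADME assay on Vero cells (Chlorocebus sabaeus) for cytotoxicity, read by MTT assay (on this read-out lower numbers stand for stronger inhibition and higher numbers for weaker inhibition), compound 3 gives 16300 nM, which places it at the high end of these numbers alongside compound 1. Compound 4 `C=CCOc1cc(OC)c(C(=O)/C=C/c2ccc(Cl)cc2)c(OCC=C)c1` changes one group: 4-chlorophenyl in place of 2-fluorophenyl on a double-bonded chain carbon bound to a double-bonded chain carbon. Going by the values given here, two measured steps bear on this. Putting 2-fluorophenyl in place of 4-fluorophenyl gave a 1.2-fold higher number from compound 1 to compound 3 (0.08 log units; within the scatter), while pyridin-2-yl in place of 4-fluorophenyl gave a 4.9-fold lower number from compound 1 to compound 2 (0.69 log units; beyond the scatter). Compound 4 keeps a ring of carbon only, like compound 1 at 13600 nM, so no step beyond the scatter is expected in this assay. Among the compounds with values here, no compound carrying chlorine has been measured, so the range stays wide. The estimated step is a 1.3-fold lower number from compound 3 to compound 4 (0.10 log units; within the scatter). Compound 4 is expected at 13000 nM, within 6000 nM to 28000 nM.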

Compound 4, half-maximal inhibitory concentration: 10400 nM
Beside the measured number, compound 4's estimate is 1.3-fold (0.10 log units) above it; low and high end bracket the measured number.
By their numbers in this assay, from the lowest: compound 2; then compounds 4, 1 and 3 (each within the scatter of the next).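

In this assay, the kind of halogen and its place on the ring make little difference here: chloro in place of fluoro gives a 1.3-fold lower number from compound 1 to compound 4 (0.12 log units; within the scatter), and 4-chlorophenyl in place of 2-fluorophenyl gives a 1.6-fold lower number from compound 3 to compound 4 (0.20 log units; within the scatter). Only pyridin-2-yl stands apart from these halogen-bearing rings of carbon only, as 4-chlorophenyl in its place gives a 3.7-fold higher number from compound 2 to compound 4 (0.57 log units; beyond the scatter). No measurement given here explains that gap. Still open, going by these compounds, is whether a phenyl ring carrying an amine, a carboxylic acid or a methoxy group at this place would group with the halogen-bearing rings or with pyridin-2-yl.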